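Swapping the aryl amine for cyclohexyl on a shared core

A few compounds are considered here, and "the series" means these few. Any claim that something is new, unique, unknown or untested is made for them only; others in the source may bear on it.

Measured compounds:
- compound 1, `COc1ccc(N/C(CCNC2=CC(=O)c3ccccc3C2=O)=N\S(=O)(=O)c2ccc(C)cc2)cc1`: 12000 nM
- compound 2, `COc1ccc(N/C(CCNC2=CC(=O)c3ccccc3C2=O)=N\S(=O)(=O)c2ccc(C)cc2)c(OC)c1`: 67300 nM
- compound 3, `Cc1ccc(S(=O)(=O)/N=C(/CCNC2=CC(=O)c3ccccc3C2=O)Nc2cc(F)c(F)c(F)c2)cc1`: 12600 nM

All three were tested in a functional assay on DU-145 cells (Homo sapiens) for cytotoxicity, read by MTT assay, with a stated time of 48 h; a higher number here means a weaker inhibitor, a lower number a stronger inhibitor. Compound 3 gives 12600 nM, the second highest of the three numbers; compound 1 sits nearest, with a 1.1-fold higher number from compound 1 to compound 3 (0.02 log units; within the scatter), while compound 2 is furthest, with a 5.3-fold lower number from compound 2 to compound 3 (0.73 log units; beyond the scatter).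

Compound 4, `Cc1ccc(S(=O)(=O)/N=C(/CCNC2=CC(=O)c3ccccc3C2=O)NC2CCCCC2)cc1`, differs from compound 3 at the amine nitrogen: cyclohexyl in place of 3,4,5-trifluorophenyl on an amine nitrogen. The aromatic ring bearing three fluorines gives way to a non-aromatic ring of six carbons.

Going by the values given here, two measured steps touch the same amine nitrogen. Between compound 1 and compound 3 the change was a 1.1-fold higher number from compound 1 to compound 3 (0.02 log units; within the scatter), so one aryl group for another left the number essentially unchanged. Between compound 2 and compound 3 the change was a 5.3-fold lower number from compound 2 to compound 3 (0.73 log units; beyond the scatter), a modest shift. Among the compounds with values here, no measured compound carries a non-aromatic group at this nitrogen, so the data give no direct guide for cyclohexyl. The expectation is therefore a step of a 1.4-fold higher number from compound 3 to compound 4 (0.15 log units; within the scatter), close to or only slightly beyond the scatter, most likely toward a somewhat higher number.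

Compound 4 is estimated at 18000 nM, within 6000 nM to 55000 nM.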

Compound 4, half-maximal inhibitory concentration: 16600 nM
For compound 4 the middle estimate is 1.1-fold (0.04 log units) above the measured one, and the stated range covers the measured number.
By their numbers in this assay, from the lowest: compounds 1, 3 and 4 (each within the scatter of the next); then compound 2.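

In this assay, putting cyclohexyl on the amine nitrogen gives a 1.3-fold higher number from compound 3 to compound 4 (0.12 log units; within the scatter) and also a 1.4-fold higher number from compound 1 to compound 4 (0.14 log units; within the scatter) and so cannot be told apart from either aryl group. Going by these compounds alone, the earlier compounds had only aryl groups at this nitrogen, so the new result adds that an aromatic ring here is not needed to stay level with compound 1 and compound 3, and that a non-aromatic ring of carbon only can take its place; the one compound that goes against this flat picture is compound 2, as the step of a 4.1-fold lower number from compound 2 to compound 4 (0.61 log units; beyond the scatter) still lies beyond the scatter. Nothing available explains why exchanging these rings changes the number so little.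

Open-chain groups at this nitrogen, such as methyl or n-butyl, are not among the compounds shown, nor are rings carrying an amine or a carboxylic acid, so it remains unknown how far this flat response extends. On these data alone, it also stays open whether cyclohexyl would behave the same way on a core with a different group in place of the shared sulfonyl part.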